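Dichloropyrimidine replaces 4-methylphenyl in compound 4

The compounds below may be only part of what the source reports. "The series", "measured", "known", "first", "only" and "open" are said of these compounds alone.

Compound 1 `Cc1ccc(C(=O)Nc2cccc(-c3oc4cc(-c5ccc(F)cc5)ccc4c(=O)c3O)c2)cc1` is the most potent of three compounds examined in a functional assay on A549 cells (Homo sapiens) for antiproliferative activity, read by CCK-8 assay, with a stated time of 72 h (a lower number here means a stronger inhibitor, a higher number a weaker inhibitor), where compound 1 gives 6910 nM. Compound 2 `O=C(Nc1cccc(-c2oc3cc(-c4ccc(F)cc4)ccc3c(=O)c2O)c1)c1ccc(F)cc1F` gives 20500 nM in this assay, and compound 3 `O=C(Nc1cccc(-c2oc3cc(-c4ccc(F)cc4)ccc3c(=O)c2O)c1)c1ccc(C(F)(F)F)cc1` gives 19400 nM. Both changes at the carbonyl carbon of compound 1 cost activity: a 3.0-fold higher number from compound 1 to compound 2 (0.47 log units; beyond the scatter), and a 2.8-fold higher number from compound 1 to compound 3 (0.45 log units; beyond the scatter). Between the two weaker compounds there is no meaningful gap, since a 1.1-fold lower number from compound 2 to compound 3 (0.02 log units; within the scatter).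

Compound 4 `O=C(Nc1cccc(-c2oc3cc(-c4ccc(F)cc4)ccc3c(=O)c2O)c1)c1cnc(Cl)nc1Cl` alters compound 1 at the same place as those two steps: 2,4-dichloropyrimidin-5-yl in place of 4-methylphenyl on a carbonyl carbon. Neither measured step involves a heteroaromatic ring or chlorine, so the guide is indirect, but in both cases departing from the 4-methylphenyl group on the carbonyl carbon raised the number by a modest amount beyond the scatter. On that basis compound 4 is expected to be weaker than compound 1, with the step estimated as a 2.6-fold higher number from compound 1 to compound 4 (0.42 log units; beyond the scatter), of the same order as the drop seen for compound 2 and compound 3. On these data alone, the estimate for compound 4 in this assay is 18000 nM, with a range of 7000 nM to 45000 nM reflecting that the new ring is untested here.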

Compound 4, half-maximal inhibitory concentration: > 100000 nM
Compound 4: a limit, no number (the forecaster's own chance of this, stated with the estimate: 10%); middle value at least 5.5-fold (0.74 log units) from the limit.
By their numbers in this assay, from the lowest: compound 1; then compounds 3 and 2 (each within the scatter of the next). At a limit, above all of these: compound 4.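

In this assay the reading for compound 4 is a limit of the assay and not a number: the limit of > 100000 nM in this assay, at which 1 of the 4 values shown sits. Replacing 4-methylphenyl with 2,4-dichloropyrimidin-5-yl gives an at least 14-fold higher number from compound 1 to compound 4 (1.16 log units; beyond the scatter) and so shows that this place on the carbonyl carbon can lose far more activity than the modest steps to compound 2 and compound 3 had revealed. The loss also holds against the two weaker compounds, with an at least 5.1-fold higher number from compound 3 to compound 4 (0.71 log units; beyond the scatter) and an at least 4.8-fold higher number from compound 2 to compound 4 (0.68 log units; beyond the scatter) so that this ring, unlike the 2,4-difluorophenyl and 4-(trifluoromethyl)phenyl groups, stands apart from the other replacements rather than alongside them.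

The compounds shown leave open whether the loss goes with the two ring nitrogens or the two chlorines, as no compound here carries one without the other. On these data alone, a 2,4-dichlorophenyl group or an unsubstituted pyrimidin-5-yl group on the same carbonyl carbon would separate the two, and whether an amine on the ring in place of either chlorine would restore any activity also remains open.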